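Stripping the Butyl Group from Compound 2

The source may hold more compounds than are shown below. What is called first, only, known or untested is meant among the compounds shown, and "the series" means these compounds.

Of the compounds shown here, three built on one shared core have been tested in a functional assay on MCF7 cells (Homo sapiens) for inhibition; on this read-out lower numbers stand for stronger inhibition and higher numbers for weaker inhibition. Compound 1 (`CCOC(=O)CNC(=O)N1CC1C#N`) gives 11000 nM, and compound 3 (`CCOC(=O)c1ccc(NC(=O)N2CC2C#N)cc1`) gives 3300 nM. Compound 2 (`CCCCNC(=O)N1CC1C#N`) reaches only a limit of this assay, > 12000 nM, so where it truly stands is not known; this is the limit of > 12000 nM in this assay, at which 1 of the 3 values shown sits. Compound 4 (`N#CC1CN1C(N)=O`) differs from compound 2 by a single change: hydrogen in place of butyl on an amide-type nitrogen. Going by the values given here, no measured pair of this kind exists among the three compounds to size the step, and the starting point is itself a limit. The step is therefore expected to stay within the scatter, as a step that the limit leaves unreadable from compound 2 to compound 4. Compound 4 is estimated at 15000 nM, with a range from 5000 nM to 50000 nM.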

Compound 4, half-maximal inhibitory concentration: > 54000 nM
Compound 4 was reported as a limit; the forecaster's own chance of this, stated with the estimate: 60%; middle value at least 3.6-fold (0.55 log units) away from the limit.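

Compound 2 and compound 4 both stand at limits of this assay, so the step between them cannot be read. The compounds shown leave open whether hydrogen in place of butyl on the amide-type nitrogen alters inhibition at all.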